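Ring-nitrogen substituent series: step to compound 3

The compounds below may be only part of what the source reports. "The series", "measured", "known", "first", "only" and "open" are said of these compounds alone.

compound 1 `CCCn1c(=O)[nH]c2nc(-c3ccc(S(=O)(=O)N4CCN(Cc5cccc(C)c5)CC4)cc3)[nH]c2c1=O` — 795 nM
compound 2 `CCCn1c(=O)[nH]c2nc(-c3ccc(S(=O)(=O)N4CCN(c5ccccc5F)CC4)cc3)[nH]c2c1=O` — > 1000 nM

In an assay on CHO cells for displacement of a labelled ligand from adenosine receptor A1 (Homo sapiens), read by scintillation counting, with a stated time of 90 min, in the presence of a further agent that is not named here (on this read-out higher numbers stand for weaker inhibition and lower numbers for stronger inhibition), compound 1 gives 795 nM. For compound 2 the assay reports only a limit, > 1000 nM. Among the measured compounds shown here, the single measured step, an at least 1.2-fold higher number from compound 1 to compound 2 (0.09 log units; that floor lies within the scatter), rests on the limit of > 1000 nM in this assay, at which 1 of the 2 values shown sits, and fixes no size beyond its floor, so compound 2 stands at the limit and nowhere more exactly. Compound 3 `CCCn1c(=O)[nH]c2nc(-c3ccc(S(=O)(=O)N4CCN(C(C)c5ccccc5)CC4)cc3)[nH]c2c1=O` is not yet measured; it differs from compound 2 by 1-phenylethyl in place of 2-fluorophenyl on an amine nitrogen in a ring. For the measured compounds named here, the group that enters resembles the 3-methylbenzyl of compound 1 more than the 2-fluorophenyl of compound 2, and the only guide is the step between those two, which lies within the scatter. Compound 3 is expected to give about 900 nM in this assay, with a range from 400 nM to 3000 nM. The expected step of an at least 1.1-fold lower number from compound 2 to compound 3 (0.04 log units; that floor lies within the scatter) is thus none beyond the scatter, with a fair chance that again only a limit is reported.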

Compound 3, inhibition constant: >= 1000 nM
Compound 3: no number, only a limit; the forecaster's own chance of this, stated with the estimate: 40%; at least 1.1-fold (0.04 log units) between middle value and limit.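

In this assay compound 3 gives only a limit, >= 1000 nM. With 1-phenylethyl in place of 3-methylbenzyl on the ring nitrogen, the series shows an at least 1.2-fold higher number from compound 1 to compound 3 (0.09 log units; that floor lies within the scatter), so a second group carrying a six-membered aromatic ring joins 2-fluorophenyl at a limit, and no step from compound 1 is yet shown beyond the scatter. Compound 2 and compound 3 both carry limits, and the step between them cannot be read.

Among the compounds shown here, compound 1 remains the only compound here with an exact number, and how far compound 2 and compound 3 lie past their limits stays open. Also open, as far as these compounds go, is what an unsubstituted benzyl, a 2-phenylethyl or a plain methyl on the same ring nitrogen would give in this assay.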